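A few compounds are considered here, and "the series" means these few. Any claim that something is new, unique, unknown or untested is made for them only; others in the source may bear on it.

Measured compounds, with their results in an assay for inhibition of high affinity nerve growth factor receptor (Homo sapiens), read by HTRF, with a stated time of 30 min, in the presence of a further agent that is not named here; on this read-out lower numbers stand for stronger inhibition and higher numbers for weaker inhibition:
compound 1 `Fc1ccc(CNc2nc(Nc3cc(C4CC4)[nH]n3)c3ccccc3n2)cc1`: 40 nM
compound 2 `Fc1ccc(CNc2nc(Nc3cc(C4CC4)[nH]n3)c3ccccc3n2)c(F)c1`: 4.7 nM
compound 3 `CCc1cc(Nc2nc(NCc3ccc(F)cc3F)nc3ccccc23)n[nH]1`: 20 nM

Compound 2 stands lowest of the three in this assay; the gaps are a 4.3-fold higher number from compound 2 to compound 3 (0.63 log units; beyond the scatter) and, from the other side, an 8.5-fold lower number from compound 1 to compound 2 (0.93 log units; beyond the scatter). Compound 4 `Fc1ccc(CNc2nc(Nc3cc(C4CC4)[nH]n3)c3cc(F)ccc3n2)c(F)c1` is not yet measured. It differs from compound 2 by fluoro in place of hydrogen on an aromatic carbon. Going by the values given here, the only measured step of the same kind, fluoro for hydrogen on an aromatic carbon, is an 8.5-fold lower number from compound 1 to compound 2 (0.93 log units; beyond the scatter), but that fluorine entered the benzyl ring, not the fused core, so it bears only loosely. The step of a 4.3-fold higher number from compound 2 to compound 3 (0.63 log units; beyond the scatter) concerns a different position. Expected for compound 4 in this assay is therefore a number close to compound 2, step a 1.2-fold lower number from compound 2 to compound 4 (0.07 log units; within the scatter), estimated at 4 nM with a range of 1.5 nM to 12 nM.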

Compound 4, half-maximal inhibitory concentration: 59 nM
For compound 4 the middle estimate is 15-fold (1.17 log units) below the measured one; the whole stated range lies below it.
By their numbers in this assay, from the lowest: compound 2; then compounds 3, 1 and 4 (each within the scatter of the next, the first and the last beyond it).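

Fluoro in place of hydrogen does not act the same way everywhere in this series: in this assay the change on the fused core gives a 13-fold higher number from compound 2 to compound 4 (1.10 log units; beyond the scatter) and stands opposite in direction to the benzyl-ring change, an 8.5-fold lower number from compound 1 to compound 2 (0.93 log units; beyond the scatter) on the same read-out. The position, meta to a fused ring and para to a fused ring, therefore accepts this one atom poorly, at least alongside the cyclopropyl and difluorobenzyl groups of compound 2. Nothing at hand accounts for the loss and the reason stays unknown.

Still open, on these data alone, is whether a methoxy, an amine or a nitrile on this carbon would fare as fluoro does. Also open, as far as these compounds go, is whether the loss carries over to the ethyl partner, compound 3.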